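The compounds below may be only part of what the source reports. "The series", "measured", "known", "first", "only" and "open" are said of these compounds alone.

Measured in a functional assay on DU-145 cells (Homo sapiens) for inhibition, read by trypan blue exclusion, with a stated time of 96 h; a higher number here means a weaker inhibitor of growth, a lower number a stronger inhibitor of growth:
Compound 1 `COc1ccc(/C=C(\C(=O)c2ccc(Br)cc2)S(=O)(=O)c2ccc(Br)cc2)cc1`: 25000 nM
Compound 2 `O=C(/C(=C\c1ccc(Br)c(O)c1)S(=O)(=O)c1ccc(Br)cc1)c1ccc(Br)cc1`: 50000 nM
Compound 3 `O=C(/C(=C\c1ccc(Cl)c([N+](=O)[O-])c1)S(=O)(=O)c1ccc(Br)cc1)c1ccc(Br)cc1`: 10000 nM

Compound 1 stands within the scatter of one neighbour and clear of the other, the measured steps being a 2.0-fold higher number from compound 1 to compound 2 (0.30 log units; within the scatter) and a 2.5-fold lower number from compound 1 to compound 3 (0.40 log units; beyond the scatter). Compound 4 `COc1ccc(/C=C(\C(=O)c2ccc(Br)cc2)S(=O)(=O)Cc2ccc(F)cc2)cc1`, not yet measured, differs from compound 1 elsewhere: 4-fluorobenzyl in place of 4-bromophenyl on a sulfonyl sulfur. Within the data shown here, no measured step changes the group at that sulfonyl sulfur. All three exchange the substituted phenyl on a double-bonded chain carbon, so they serve only as a gauge of size, the largest being a 5.0-fold lower number from compound 2 to compound 3 (0.70 log units; beyond the scatter). In this assay, no change beyond the scatter is therefore expected, in either direction. The estimated step is a 1.7-fold lower number from compound 1 to compound 4 (0.22 log units; within the scatter). Compound 4 is expected at 15000 nM, with an estimated range from 4000 nM to 50000 nM.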

Compound 4, concentration for 50% growth inhibition: 25000 nM
For compound 4 the middle estimate is 1.7-fold (0.22 log units) below the measured one, and the stated range covers the measured number.
By their numbers in this assay, from the lowest: compound 3; then compounds 1, 4 and 2 (each within the scatter of the next).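

In this assay, among these compounds, the sulfonyl sulfur becomes a readable position for the first time, and 4-fluorobenzyl in place of 4-bromophenyl gives no change at the digits printed from compound 1 to compound 4 (within the scatter) in the core of compound 1. The number at this position therefore holds through a change of both the halogen and the carbon count of the group. Nothing measured here bears on the reason for this result.

The compounds shown leave open whether those two changes each leave the number alone or offset one another, which a 4-fluorophenyl group could separate. On these data alone, how an amine on that sulfonyl sulfur would read also remains open, as does whether the same exchange would hold on compound 3.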